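A few compounds are considered here, and "the series" means these few. Any claim that something is new, unique, unknown or untested is made for them only; others in the source may bear on it.

Measured in a functional assay on MDA-MB-231 cells (Homo sapiens) for antiproliferative activity, read by sulforhodamine B assay; a higher number here means a weaker inhibitor of growth, a lower number a stronger inhibitor of growth:
- compound 1 `CC(C)CCCOc1cccc(O)c1C(=O)/C=C/c1ccc(O)cc1`: 3480 nM
- compound 2 `CCCCCCOc1cccc(O)c1C(=O)/C=C/c1ccc(O)cc1`: > 30000 nM (a limit)
- compound 3 `CC(C)=CCOc1cccc(O)c1C(=O)/C=C/c1ccc(O)cc1`: > 30000 nM (a limit)

Compound 3 gives no number, only a limit, and that is the limit of > 30000 nM in this assay, at which 2 of the 3 values shown sit.

Compound 4 `O=C(/C=C/c1ccc(O)cc1)c1c(O)cccc1OCCC1CCCCC1` carries cyclohexylmethyl in place of 2-methylprop-1-en-1-yl on a saturated chain carbon bound to an oxygen on an aromatic ring.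

Going by the values given here, two measured steps bear on this change: an at least 8.6-fold higher number from compound 1 to compound 3 (0.93 log units; beyond the scatter) and an at least 8.6-fold higher number from compound 1 to compound 2 (0.93 log units; beyond the scatter). Only compound 1 gives a number, and the saturated chain of compound 2 goes against any simple rule for saturated chains. The step that the two limits leave unreadable from compound 2 to compound 3 adds nothing.

A lower number in this assay is expected, of modest size, though compound 4 may also stop at the limit. The estimated step is an at least 2.5-fold lower number from compound 3 to compound 4 (0.39 log units; beyond the scatter). The estimate for compound 4 is 12000 nM, with an expected range of 3500 nM to 30000 nM.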

Compound 4, concentration for 50% growth inhibition: > 30000 nM
Compound 4: only a limit was reported; the forecaster's own chance of this, stated with the estimate: 45%; at least 2.5-fold (0.39 log units) between middle value and limit.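

At this position, 2-cyclohexylethyl joins the groups that reach only a limit in this assay: the limit of > 30000 nM in this assay, at which 3 of the 4 values shown sit.

Placing a six-membered non-aromatic ring on the chain does not bring back the activity of compound 1, and the change gives an at least 8.6-fold higher number from compound 1 to compound 4 (0.93 log units; beyond the scatter). Going by these compounds alone, the steps among compound 2, compound 3 and compound 4 cannot be read, which leaves compound 1 as the only compound here with a number.

On these data alone, whether a chain carrying an amine or a carboxylic acid would give a number at this position stays open. As far as these compounds go, how compound 2, compound 3 and compound 4 rank against one another also stays open.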